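The source may hold more compounds than are shown below. What is called first, only, known or untested is meant among the compounds shown, and "the series" means these compounds.

Measured in a functional assay on K562 cells (Homo sapiens), read by MTT assay, with a stated time of 72 h; a lower number here means a stronger inhibitor, a higher number a weaker inhibitor:
- Compound 1 `CSc1ncnc2c1c(-c1ccoc1)cn2[C@@H]1O[C@H](CO)[C@@H](O)[C@H]1O`: 60 nM
- Compound 2 `CSc1ncnc2c1c(-c1cccs1)cn2[C@@H]1O[C@H](CO)[C@@H](O)[C@H]1O`: 11600 nM
- Compound 3 `CNc1ncnc2c1c(-c1ccco1)cn2[C@@H]1O[C@H](CO)[C@@H](O)[C@H]1O`: 220 nM

Compound 3 holds the middle place of these three values, with compound 1 lower and compound 2 higher. Compound 4 `CNc1ncnc2c1c(-c1ccccc1)cn2[C@@H]1O[C@H](CO)[C@@H](O)[C@H]1O` differs from compound 3 by phenyl in place of furan-2-yl on an aromatic carbon. Within the data shown here, no measured compound carries phenyl. Among the measured compounds shown here, the one measured step that bears on this change is a different swap on a different compound pair, thiophen-2-yl in place of furan-3-yl, which gave a 190-fold higher number from compound 1 to compound 2 (2.29 log units; beyond the scatter). It shows only that replacing a furan can cost much, so a clearly higher number is expected in this assay, though probably a smaller rise than that one. The expected step is a 9.1-fold higher number from compound 3 to compound 4 (0.96 log units; beyond the scatter). For compound 4 the estimated value is 2000 nM, within an expected range of 350 nM to 11000 nM.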

Compound 4, half-maximal inhibitory concentration: > 20000 nM
Compound 4 gave a limit, no number (the forecaster's own chance of this, stated with the estimate: 15%); middle value at least 10-fold (1.00 log units) from the limit.
By their numbers in this assay, from the lowest: compound 1; then compound 3; then compound 2. At a limit, above all of these: compound 4.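

Phenyl in place of furan-2-yl gave an at least 90-fold higher number from compound 3 to compound 4 (1.95 log units; beyond the scatter) in this assay. So at this aromatic carbon, two ring bonds from the ring nitrogen, a six-membered aromatic ring of carbon only is far from interchangeable with the furan, and this now holds for a direct change on compound 3 rather than for a swap between two five-membered rings. Compound 4 stands at a limit and not at a number: the limit of > 20000 nM in this assay, at which 1 of the 4 values shown sits.

Going by these compounds, how far the true step extends past that limit stays open. So does how an amine or a short alkyl chain on this carbon would compare with furan-2-yl.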